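A few compounds are considered here, and "the series" means these few. Any claim that something is new, unique, unknown or untested is made for them only; others in the source may bear on it.

Measured so far in an assay on isolated protein for binding affinity to adenosine receptor A1 (Bos taurus); a higher number here means a weaker inhibitor, a lower number a stronger inhibitor:
- compound 1, `CCCNc1nc(-c2ccccc2)nc2c1nnn2Cc1ccccc1F`, gives 3200000 nM
- compound 2, `CCCNc1nc(-c2ccccc2)nc2c1nnn2Cc1ccccc1`, gives 37000000 nM
- compound 3, `CCNc1nc(-c2ccccc2)nc2c1nnn2Cc1ccccc1F`, gives 11000000 nM

All three numbers are high, and compound 3 sits between compound 1 and compound 2 on these values. Compound 4, `CCNc1nc(-c2ccccc2)nc2c1nnn2Cc1ccccc1`, is not yet measured in this assay. It differs from compound 3 by hydrogen in place of fluoro on an aromatic carbon.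

The same change already stands between two measured compounds: compound 2 differs from compound 1 by hydrogen in place of fluoro on an aromatic carbon, and in this assay that step is a 12-fold higher number from compound 1 to compound 2 (1.06 log units; beyond the scatter). The place of the change reads the same, word for word, in both pairs, so this is the same change made on a different core. The two cores differ in that compound 3 differs from compound 1 by hydrogen in place of methyl on a saturated chain carbon, two bonds along the chain from a nitrogen on an aromatic ring; in this assay that step is a 3.4-fold higher number from compound 1 to compound 3 (0.54 log units; beyond the scatter).

Among the measured compounds shown here, only one measured example of the change exists, so the basis for transfer is thin. Still, the step from compound 3 to compound 4 in this assay is expected to read an 11-fold higher number from compound 3 to compound 4 (1.04 log units; beyond the scatter), of the same order as the earlier step, because it rests on a 12-fold higher number from compound 1 to compound 2 (1.06 log units; beyond the scatter). Compound 4 is therefore estimated at 120000000 nM in this assay, with an expected range from 35000000 nM to 450000000 nM. Given how high the numbers already run, the assay may well return only a limit for compound 4.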

Compound 4, inhibition constant: 91000000 nM
Compound 4: middle estimate off by 1.3-fold (0.12 log units), on the high side, and the stated range covers the measured number.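

In this assay, hydrogen in place of fluoro on the core of compound 3 gives an 8.3-fold higher number from compound 3 to compound 4 (0.92 log units; beyond the scatter), and this step carries over from the core of compound 1 without a meaningful difference in size: the same change on two cores in this assay, a 12-fold higher number (1.06 log units; beyond the scatter) from compound 1 to compound 2 and an 8.3-fold higher number (0.92 log units; beyond the scatter) from compound 3 to compound 4, 1.4-fold (0.15 log units) apart, within the scatter of two such steps. Hydrogen in place of methyl on the saturated chain carbon, read on the benzyl compounds, gives a 2.5-fold higher number from compound 2 to compound 4 (0.39 log units; beyond the scatter), and it also carries over from the 2-fluorobenzyl compounds: the same change on two cores in this assay, a 3.4-fold higher number (0.54 log units; beyond the scatter) from compound 1 to compound 3 and a 2.5-fold higher number (0.39 log units; beyond the scatter) from compound 2 to compound 4, 1.4-fold (0.15 log units) apart, within the scatter of two such steps. These two agreements come from the same four compounds and so count as a single observation of two changes adding up, which shows transfer only between these closely related cores and only among very high numbers, and does not show that it would hold on a different core or among much lower numbers in this assay.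

The compounds shown leave open whether the 2-fluorobenzyl to benzyl step would keep its size with chloro or methoxy in place of fluoro on the same aromatic ring. Also open, on these data alone, is how a longer chain or a cyclopentyl group on the nitrogen would combine with either benzyl group.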